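The source may hold more compounds than are shown below. What is called first, only, known or untested is meant among the compounds shown, and "the series" means these compounds.

Measured so far in a functional assay on cardiac atrium (Cavia porcellus); on this read-out lower numbers stand for an effect already at smaller amounts and higher numbers for an effect only at larger amounts of compound:
- compound 1 `COC(=O)C1=C(C)NC(C)=C(C(=O)OC)C1c1c(-c2ccsc2)nc2sc(C)cn12`: 2300 nM
- compound 2 `COC(=O)C1=C(C)NC(C)=C(C(=O)OC)C1c1c(-c2cccs2)nc2sc(C)cn12`: 40500 nM

Compound 1 holds the lowest of the two numbers in this assay; its nearest neighbour is compound 2, reached by an 18-fold higher number from compound 1 to compound 2 (1.25 log units; beyond the scatter), a single exchange on an aromatic carbon of the shared core.

Compound 3 `COC(=O)C1=C(C)NC(C)=C(C(=O)OC)C1c1c(-c2cccnc2)nc2sc(C)cn12` has not been measured. It differs from compound 1 in one place: pyridin-3-yl in place of thiophen-3-yl on an aromatic carbon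

For the measured compounds named here, the only measured step, an 18-fold higher number from compound 1 to compound 2 (1.25 log units; beyond the scatter), concerns the exchange of one thiophene attachment for another at the same aromatic carbon, not the exchange of a five-membered for a six-membered ring. It shows that this position tolerates change poorly in at least one direction, but it does not tell which way the exchange of thiophen-3-yl for pyridin-3-yl will run. Going by the values given here, no measured pair bears directly on the step from compound 1 to compound 3. The expectation for compound 3 is therefore a modest move toward a higher number, a 2.0-fold higher number from compound 1 to compound 3 (0.29 log units; within the scatter), with a wide range on either side.

For compound 3 in this assay the estimate is 4500 nM, expected to fall between 900 nM and 25000 nM.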

Compound 3, half-maximal effective concentration: 12500 nM
The estimate for compound 3 lay 2.8-fold (0.44 log units) below the measured number; measured number inside the range.
By their numbers in this assay, from the lowest: compound 1; then compound 3; then compound 2.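

In this assay, for the compounds shown here, pyridin-3-yl gives the first reading for a six-membered ring at this aromatic carbon, and the exchange for thiophen-3-yl gives a 5.4-fold higher number from compound 1 to compound 3 (0.74 log units; beyond the scatter) at this position. Set against the other thiophene, the same group gives a 3.2-fold lower number from compound 2 to compound 3 (0.51 log units; beyond the scatter) so a six-membered ring is tolerated better here than thiophen-2-yl, though not as well as thiophen-3-yl, and ring size alone does not set the order of the three compounds. What now stands out is that the two thiophene attachments lie on either side of pyridin-3-yl, with every step among the three beyond the scatter, while the data at hand offer no explanation for this order.

The compounds shown leave open how phenyl, a six-membered aromatic ring with no hetero atom, would compare with pyridin-3-yl and so whether the ring nitrogen matters at all at this carbon. Also open, going by these compounds, is whether the pyridine attached through another ring carbon, or a pyridin-3-yl ring carrying an amine or a methoxy group, would approach compound 1 or fall toward compound 2.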